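The compounds below may be only part of what the source reports. "The series", "measured", "known", "first", "only" and "open" are said of these compounds alone.

Compound 2 `COc1cc(-c2nn(-c3cccc(NC(=O)Nc4cccc(C(F)(F)F)c4)c3)cc2-c2ccncc2)ccc1Cl` serves as the point of reference for this small set. In a functional assay on MDA-MB-231 cells (Homo sapiens) for inhibition, read by sulforhodamine B assay, with a stated time of 48 h (a lower number here means a stronger inhibitor of growth, a higher number a weaker inhibitor of growth), compound 2 gives 2370 nM. Compound 1 `O=C(Nc1cccc(-n2cc(-c3ccncc3)c(-c3ccc(Cl)c(O)c3)n2)c1)Nc1cccc(C(F)(F)F)c1` differs from it by hydrogen in place of methyl on an oxygen on an aromatic ring; in this assay compound 1 gives 26800 nM, and the step is an 11-fold higher number from compound 2 to compound 1 (1.05 log units; beyond the scatter). Compound 3 `COc1cc(-c2nn(-c3cccc(NC(=O)Nc4ccc(Cl)c(C(F)(F)F)c4)c3)cc2-c2ccncc2)ccc1Cl` carries a different change, (chloro in place of hydrogen on an aromatic carbon); in this assay compound 3 gives 2600 nM, and the step is a 1.1-fold higher number from compound 2 to compound 3 (0.04 log units; within the scatter), so compound 2 and compound 3 behave alike here. Compound 4 `O=C(Nc1cccc(-n2cc(-c3ccncc3)c(-c3ccc(Cl)c(O)c3)n2)c1)Nc1ccc(Cl)c(C(F)(F)F)c1` has not yet been measured in this assay. It differs from compound 3 by hydrogen in place of methyl on an oxygen on an aromatic ring, the same change at the same place as that from compound 2 to compound 1, now made on the core of compound 3. Among the compounds with values here, that earlier step, an 11-fold higher number from compound 2 to compound 1 (1.05 log units; beyond the scatter), is the only guide available. Starting from compound 3 with 2600 nM, compound 4 is expected to show a step of about an 11-fold higher number from compound 3 to compound 4 (1.03 log units; beyond the scatter), because the same change produced an 11-fold higher number from compound 2 to compound 1 (1.05 log units; beyond the scatter) in the one case where it was measured. Compound 4 is therefore estimated at 28000 nM, plausibly between 12000 nM and 65000 nM.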

Compound 4, concentration for total growth inhibition: 1440 nM
Beside the measured number, compound 4's estimate is 19-fold (1.29 log units) above it; the measured number lies below the stated range.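

In this assay, the change from methoxy to hydroxy gives a 1.8-fold lower number from compound 3 to compound 4 (0.26 log units; within the scatter), so the large step seen on the core of compound 2 did not carry over to the core of compound 3: the same change on two cores in this assay, an 11-fold higher number (1.05 log units; beyond the scatter) from compound 2 to compound 1 and a 1.8-fold lower number (0.26 log units; within the scatter) from compound 3 to compound 4, 20-fold (1.31 log units) apart, beyond the scatter of two such steps. The same four compounds can be read the other way, as chloro in place of hydrogen on an aromatic carbon gives a 19-fold lower number from compound 1 to compound 4 (1.27 log units; beyond the scatter) on the hydroxy core, whereas this change left the methoxy pair alike: the same change on two cores in this assay, a 1.1-fold higher number (0.04 log units; within the scatter) from compound 2 to compound 3 and a 19-fold lower number (1.27 log units; beyond the scatter) from compound 1 to compound 4, 20-fold (1.31 log units) apart, beyond the scatter of two such steps. This shows that, among these four compounds, the outcome of each change depends on the core that carries it, so a step measured on one core is no safe guide to another; it does not show why the two cores differ, and a single set of four compounds gives no general rule for the series.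

The compounds shown leave open how an ethoxy group or a longer alkoxy chain would behave in place of the methoxy on each core. They also leave open whether fluoro or a nitrile in place of the added chloro would give the same dependence on the core.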